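The source may report more compounds than this note shows. Statements on the series, on what has been measured and on what is new or still open speak of the compounds shown alone.

Measured so far:
compound 1 `O=C(O)/C=C/c1ccc2noc(-c3ccc(Oc4ccccc4)cc3)c2c1` — 760 nM
compound 2 `CNC(=O)c1ccc2noc(-c3ccccc3)c2c1` — 6830 nM
compound 3 `O=C(O)c1ccc2noc(-c3cccc(C(F)(F)F)c3)c2c1` — 4620 nM

In an assay for inhibition of inositol hexakisphosphate kinase 3 (Homo sapiens), read by colorimetric assay, coupled enzyme assay and malachite green, with a stated time of 120 min, in the presence of a further agent that is not named here (a higher number here means a weaker inhibitor, a lower number a stronger inhibitor), compound 3 gives 4620 nM, the second highest of the three numbers. Compound 2 lies nearest with 6830 nM, within the scatter. Compound 1 sits furthest with 760 nM, a lower number beyond the scatter.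

Compound 4 `O=C(O)c1ccc2noc(-c3cccc(Oc4ncc(Cl)cc4Cl)c3)c2c1` differs from compound 3 in one place: (3,5-dichloropyridin-2-yl)oxy in place of trifluoromethyl on an aromatic carbon. Among the measured compounds shown here, no two measured compounds differ in a single place, so no step size is known from the data. Compound 1, the only measured compound carrying an aryloxy group on its pendant ring, gives 760 nM, and that number is the lowest shown; on that basis a downward step is expected, a 3.1-fold lower number from compound 3 to compound 4 (0.49 log units; beyond the scatter), though compound 1 also differs in its acid-bearing chain. Compound 4 is expected at 1500 nM, between 500 nM and 5000 nM.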

Compound 4, half-maximal inhibitory concentration: 3090 nM
Compound 4: the middle estimate sits 2.1-fold (0.31 log units) below what was measured; the range from low to high includes it.
By their numbers in this assay, from the lowest: compound 1; then compounds 4, 3 and 2 (each within the scatter of the next, the first and the last beyond it).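

Placing (3,5-dichloropyridin-2-yl)oxy in place of trifluoromethyl on this aromatic carbon, meta to a large group, gives a 1.5-fold lower number from compound 3 to compound 4 (0.17 log units; within the scatter), the only single-place step available in the series. The entering group brings 9 heavy atoms and one six-membered aromatic ring against 4 heavy atoms and no ring, yet the number stays within the scatter. No measured evidence bears on why this change leaves the number so close.

Open, from the compounds shown here alone, is whether an amine, a methoxy group or plain hydrogen on this carbon would move the number. Also open, going by these compounds, is whether (3,5-dichloropyridin-2-yl)oxy would give a similar number on another carbon of that ring.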